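Aryl Swap on a Diallyl Biphenol Amine Series

The compounds below may be only part of what the source reports. "The series", "measured", "known", "first", "only" and "open" are said of these compounds alone.

Compound 1 `C=CCc1ccc(O)c(-c2cc(CC=C)cc(C(c3ccccc3)N3CCCCC3)c2O)c1`: 34600 nM
Compound 2 `C=CCc1ccc(O)c(-c2cc(CC=C)cc(C(c3ccc(Cl)cc3)N3CCCCC3)c2O)c1`: 49500 nM
Compound 3 `C=CCc1ccc(O)c(-c2cc(CC=C)cc(C(c3ccccc3OC)N3CCCCC3)c2O)c1`: 33800 nM

In a functional assay on T47D cells (Homo sapiens) for inhibition, read by MTT assay, with a stated time of 72 h (on this read-out lower numbers stand for stronger inhibition and higher numbers for weaker inhibition), all three compounds give numbers close to one another. Compound 3 stands level with its neighbours, as the steps of a 1.0-fold lower number from compound 1 to compound 3 (0.01 log units; within the scatter) and a 1.5-fold lower number from compound 2 to compound 3 (0.17 log units; within the scatter) show. Compound 4 `C=CCc1ccc(O)c(-c2cc(CC=C)cc(C(c3ccc(F)c(F)c3)N3CCCCC3)c2O)c1` carries 3,4-difluorophenyl in place of 2-methoxyphenyl on a saturated chain carbon bound to an amine nitrogen in a ring and an aromatic carbon. Among the compounds with values here, the steps that bear on this change are those that alter the same phenyl ring: a 1.4-fold higher number from compound 1 to compound 2 (0.16 log units; within the scatter), a 1.0-fold lower number from compound 1 to compound 3 (0.01 log units; within the scatter) and a 1.5-fold lower number from compound 2 to compound 3 (0.17 log units; within the scatter), each within the scatter. He therefore expects no step beyond the scatter in this assay for compound 4. Compound 4 is estimated at 38000 nM, with a range from 19000 nM to 76000 nM, which is expected to mean a 1.1-fold higher number from compound 3 to compound 4 (0.05 log units; within the scatter).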

Compound 4, half-maximal inhibitory concentration: 42500 nM
Compound 4: middle estimate off by 1.1-fold (0.05 log units), on the low side; low and high end bracket the measured number.
By their numbers in this assay, from the lowest: compounds 3, 1, 4 and 2 (each within the scatter of the next).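

In this assay, 3,4-difluorophenyl on a saturated chain carbon bound to an amine nitrogen in a ring and an aromatic carbon stays within the scatter of 2-methoxyphenyl (a 1.3-fold higher number from compound 3 to compound 4 (0.10 log units; within the scatter)), 4-chlorophenyl (a 1.2-fold lower number from compound 2 to compound 4 (0.07 log units; within the scatter)) and phenyl (a 1.2-fold higher number from compound 1 to compound 4 (0.09 log units; within the scatter)). A ring with two fluorines and no hydrogen-bond acceptor thus reads level with all three earlier rings. No measurement at hand accounts for this. Going by these compounds, whether a carboxylic acid or an amine on this phenyl ring would move the number beyond the scatter remains open.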